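The source may report more compounds than this note shows. Statements on the series, on what has been measured and on what is new or still open speak of the compounds shown alone.

Of the compounds shown here, two have been measured so far in a functional assay on the whole organism (blood) with Rattus norvegicus as the target, with stated times of 24 h and 1 h, at a dose of 5 mg/kg by the intraperitoneal route; a higher number here means a stronger effect of the compound at the dose given, a lower number a weaker effect. Compound 1, `CC(=O)NCCC1CCN(S(=O)(=O)NC(=O)NC[C@@H]2C[C@@H]3C=C[C@@H]2C3)CC1`, gives 18% in this assay. Compound 2, `O=C(NC1CCCCC1)NS(=O)(=O)N1CCC(CCNC(=O)c2ccc3ccccc3n2)CC1`, gives 11% in this assay. These two numbers lie within the usual scatter of this assay of each other. Among the compounds with values here, no step between the two measured compounds can be stated, since they differ in more than one place.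

Compound 3, `O=C(NC[C@@H]1C[C@@H]2C=C[C@@H]1C2)NS(=O)(=O)N1CCC(CCNC(=O)c2ccc3ccccc3n2)CC1`, has not yet been measured in this assay. It differs from compound 2 in one place: a group of 8 heavy atoms (8 carbon; 2 five-membered non-aromatic rings of carbon only) in place of a group of 6 heavy atoms (6 carbon; one six-membered non-aromatic ring of carbon only), on an amide-type nitrogen. The group that enters is the same group of 8 heavy atoms with 2 five-membered non-aromatic rings that compound 1 carries on its own amide-type nitrogen, while the rest of compound 3 is the shared core of compound 2.

Because compound 1 gives only 18% with that group in place, and because compound 2 gives 11%, a step of a number 4 percentage points higher from compound 2 to compound 3 (within the scatter) from compound 2 to compound 3 is expected, which would not go beyond the scatter. Compound 3 is therefore estimated at 15% in this assay, with a range from 5% to 28%.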

Compound 3, a percentage reported as activity, at one dose (the size of the read-out at that dose, not a potency): 21%
Compound 3: middle estimate off by 6 percentage points, on the low side; low and high end bracket the measured number.
By their numbers in this assay, from the lowest: compounds 2, 1 and 3 (each within the scatter of the next).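

On the amide-type nitrogen, cyclohexyl can be replaced by the group with 2 five-membered non-aromatic rings, 1 double bond outside aromatic rings and 3 defined stereocentres, and in this assay the result is a number 10 percentage points higher from compound 2 to compound 3 (within the scatter), so on this shared core the two groups are not told apart at this position. The second step, quinolin-2-yl in place of methyl on a carbonyl carbon, gives a number 3 percentage points higher from compound 1 to compound 3 (within the scatter) in this assay, which shows that with the group of 8 heavy atoms held fixed, the change at the other end of the molecule does not separate the compounds either. Nothing at hand bears on why the read-out stays where it does.

Going by these compounds, it remains open whether any other group on this amide-type nitrogen, such as a phenyl ring, or a chain ending in an amine or a carboxylic acid, would move the read-out beyond the scatter. Because each number is the size of the effect at a single dose, these compounds also leave open how their potencies compare.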